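An Amine-Bearing Side Chain in Place of Isopentyl

A few compounds are considered here, and "the series" means these few. Any claim that something is new, unique, unknown or untested is made for them only; others in the source may bear on it.

Compound 1 `CC(C)CCCN(C(=O)[C@@H]1C[C@H]1c1ccccc1)c1ccc(-c2ccccc2)cc1` is the starting point. In a functional assay for agonist activity at G protein-coupled receptor 88 (Homo sapiens), read by HTRF and cAMP accumulation (on this read-out lower numbers stand for an effect already at smaller amounts and higher numbers for an effect only at larger amounts of compound), compound 1 gives > 100 nM, which is a limit of the assay rather than a number (the limit of > 100 nM in this assay, at which 1 of the 3 values shown sits). Two close relatives carry an amine-bearing chain where compound 1 carries an isopentyl group. Compound 2 `CN[C@@H](CC(C)C)CN(C(=O)[C@@H]1C[C@H]1c1ccccc1)c1ccc(-c2ccccc2)cc1` gives 2 nM in this assay, and compound 3 `N[C@@H](CC1CCCCC1)CN(C(=O)[C@@H]1C[C@H]1c1ccccc1)c1ccc(-c2ccccc2)cc1` gives 1.7 nM. Both steps from compound 1 are large: an at least 50-fold lower number from compound 1 to compound 2 (1.69 log units; beyond the scatter) and an at least 58-fold lower number from compound 1 to compound 3 (1.76 log units; beyond the scatter). Between the two amine-bearing compounds the difference is small, a 1.2-fold lower number from compound 2 to compound 3 (0.07 log units; within the scatter), so nothing separates them.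

Compound 4 `CO[C@H](C)[C@H](N)CN(C(=O)[C@@H]1C[C@H]1c1ccccc1)c1ccc(-c2ccccc2)cc1` follows the same line. It differs from compound 1 by 1-amino-2-methoxypropyl in place of isopentyl on a saturated chain carbon bound to an amide-type nitrogen. Like compound 3, it carries a free amino group on the saturated chain carbon bound to the amide-type nitrogen, while the remainder of the chain differs. Because the steps of an at least 58-fold lower number from compound 1 to compound 3 (1.76 log units; beyond the scatter) and an at least 50-fold lower number from compound 1 to compound 2 (1.69 log units; beyond the scatter) were large and in the same direction, a large step toward a lower number is expected here as well. The expected step is an at least 20-fold lower number from compound 1 to compound 4 (1.30 log units; beyond the scatter). Compound 4 is therefore estimated at 5 nM, with a likely range from 1.5 nM to 30 nM.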

Compound 4, half-maximal effective concentration: 0.68 nM
Compound 4: middle estimate off by 7.4-fold (0.87 log units), on the high side, and the stated range ends above it.
By their numbers in this assay, from the lowest: compound 4; then compounds 3 and 2 (each within the scatter of the next). At a limit, above all of these: compound 1.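

With 1-amino-2-methoxypropyl in place of isopentyl on a saturated chain carbon bound to an amide-type nitrogen, this assay shows an at least 140-fold lower number from compound 1 to compound 4 (2.16 log units; beyond the scatter), the largest step from the starting point so far, so the amine-bearing chain keeps its effect when its remainder carries an ether oxygen. That step gives only a minimum size, as the value for compound 1 is not a number but a limit: the limit of > 100 nM in this assay, at which 1 of the 4 values shown sits. The new compound also separates from the two earlier amine-bearing compounds, which themselves stayed within the scatter of each other: 1-methoxyethyl in place of cyclohexylmethyl gives a 2.5-fold lower number from compound 3 to compound 4 (0.40 log units; beyond the scatter), and the change from the chain of compound 2 gives a 2.9-fold lower number from compound 2 to compound 4 (0.47 log units; beyond the scatter), although that second step also removes the methyl group on the amine nitrogen.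

The compounds shown do not tell whether the amino group or the methoxy group accounts for the low number in compound 4, as no chain here carries the methoxy group without the amine. From the compounds shown here alone, it also stays open whether a hydroxyl group in place of the methoxy group would hold this level, and whether the two defined stereocentres matter, as only one arrangement of them appears here.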